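The compounds below may be only part of what the source reports. "The series", "measured", "known", "first", "only" and "open" are said of these compounds alone.

Compound 1 `C/C(=C\CC/C(C)=C/CC[C@@H]1[C@@]2(C)CCC(=O)C(C)(C)[C@H]2CC[C@@]1(C)O)CC/C=C(\C)C(=O)OCc1cn(-c2cccc(Br)c2)nn1` was tested in an ADME assay on L132 cells (Homo sapiens) for cytotoxicity, read by MTT assay, with a stated time of 48 h; on this read-out higher numbers stand for weaker inhibition and lower numbers for stronger inhibition. In this assay compound 1 gives > 150000 nM, which is a limit of the assay rather than a number. Compound 2 `C/C(=C\CC/C(C)=C/CC[C@@H]1[C@@]2(C)CCC(=O)C(C)(C)[C@H]2CC[C@@]1(C)O)CC/C=C(\C)C(=O)O` shares the core of compound 1 and was tested in this assay as well. In this assay compound 2 gives > 150000 nM, again a limit. Within the data shown here, both values therefore stand at the limit of > 150000 nM in this assay, at which 2 of the 2 values shown sit, and no measured pair here shows a step from one number to another. Compound 3 `C/C(=C\CC/C(C)=C/CC[C@@H]1[C@@]2(C)CCC(=O)C(C)(C)[C@H]2CC[C@@]1(C)O)CC/C=C(\C)C(=O)OCc1cn(-c2cccc(O)c2)nn1` has not yet been measured. It differs from compound 1 by hydroxy in place of bromo on an aromatic carbon. Among the measured compounds shown here, with no measured step to go by, the expected step that the limit leaves unreadable from compound 1 to compound 3 is none beyond the scatter, because compound 1 already sits at the limit of > 150000 nM in this assay, at which 2 of the 2 values shown sit. Compound 3 is therefore expected to give about 200000 nM, with a range from 100000 nM to 400000 nM, and most likely a limit again rather than a number.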

Compound 3, half-maximal inhibitory concentration: 146000 nM
Beside the measured number, compound 3's estimate is 1.4-fold (0.14 log units) above it; measured number inside the range.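

Of the three compounds shown, only compound 3 gives a number rather than a limit in this assay, so this position on the aromatic ring now has one measured end. Putting hydroxy in place of bromo gives an at least 1.0-fold lower number from compound 1 to compound 3 (0.01 log units; that floor lies within the scatter), which means that this change shows no shift that can be told apart from the scatter. How large the real step is stays unknown, since its other end is a limit: the limit of > 150000 nM in this assay, at which 2 of the 3 values shown sit.

The compounds shown leave open whether another group at this place, such as an amine, a carboxylic acid or a methoxy group, would give a clearly lower number. They also leave open whether moving the hydroxy elsewhere on the six-membered ring would change the read-out.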